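The source may hold more compounds than are shown below. What is called first, only, known or untested is meant among the compounds shown, and "the series" means these compounds.

Compound 1 `COc1ccc([C@@H]2[C@@H](C(=O)c3ccsc3)C(=O)N2c2cc(OC)c(OC)c(OC)c2)cc1` gives 470 nM in a functional assay on MCF7 cells (Homo sapiens) for antiproliferative activity, read by MTT assay; on this read-out lower numbers stand for stronger inhibition and higher numbers for weaker inhibition.
Compound 2 `COc1ccc([C@@H]2C(c3ccoc3)C(=O)N2c2cc(OC)c(OC)c(OC)c2)cc1` gives 150 nM in this assay.
Compound 3 `COc1ccc([C@@H]2[C@@H](c3cccs3)C(=O)N2c2cc(OC)c(OC)c(OC)c2)cc1N` gives 42 nM in this assay.

Among the three measured compounds, compound 1 stands at the highest number in this assay, with 470 nM. Compound 2 gives 150 nM and compound 3 gives 42 nM, so both sit well below compound 1, and in both cases the gap exceeds the usual scatter of repeated measurements. Compound 1 is therefore the weakest of the three on this read-out.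

The unmeasured compound 4 `COc1ccc([C@@H]2[C@@H](C(O)c3ccoc3)C(=O)N2c2cc(OC)c(OC)c(OC)c2)cc1` follows from compound 1 by a single change: (furan-3-yl)(hydroxy)methyl in place of (thiophen-3-yl)carbonyl on a saturated ring carbon. The shared core and the 4-methoxyphenyl group are unchanged, as is the trimethoxyphenyl group on the ring nitrogen. Within the data shown here, no step between measured compounds isolates this change, and nothing among the three values speaks directly to a hydroxymethyl linker. Compound 2 does show that a five-membered ring attached without a carbonyl can go with a lower number than compound 1, but its ring is joined directly and is not a like-for-like comparison. A step of modest size toward a lower number, or none beyond the scatter, is the expectation here.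

On that basis compound 4 is estimated at 350 nM in this assay, within a range of 120 nM to 1000 nM, which means an expected step of a 1.3-fold lower number from compound 1 to compound 4 (0.13 log units; within the scatter).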

Compound 4, half-maximal inhibitory concentration: 1100 nM
Beside the measured number, compound 4's estimate is 3.1-fold (0.50 log units) below it; measured number above the stated range.
By their numbers in this assay, from the lowest: compound 3; then compound 2; then compound 1; then compound 4.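

In this assay, among these compounds, the step gives the first reading at this position, the saturated ring carbon of the four-membered ring: a 2.3-fold higher number from compound 1 to compound 4 (0.37 log units; beyond the scatter). The position is therefore not indifferent to what it carries, since a modest move beyond the scatter appears even though the leaving and entering groups both have 7 heavy atoms and one five-membered aromatic ring with 1 hetero atom. The change is a double one, however, with the carbonyl giving way to a hydroxy-bearing carbon and thiophene giving way to furan, and the step reports only their combined outcome. No measurement here bears on why the number rises.

The compounds shown leave open which part of the change accounts for the step, a question that (furan-3-yl)carbonyl or (thiophen-3-yl)(hydroxy)methyl at this position could separate. They also leave open how this position would respond to an amine in place of the hydroxy group, or to a longer chain between the ring carbon and the five-membered ring.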